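Removing a Chloro Group From an Inactive Hydrazone

This account rests on a few compounds, and the source may have more. Where it says the series, first, only, none or still open, it means among the compounds named here.

Among the measured compounds shown here, compound 1 `COc1ccc(OC)c(/C=C/c2nnc(Nc3ccc(Cl)cc3)o2)c1` and compound 2 `COc1ccc(OC)c(/C=C/C(=O)N/N=C/c2ccc(Cl)cc2)c1` are the two measured members of this set. In a functional assay on UACC-257 cells (Homo sapiens) for antiproliferative activity, read by sulforhodamine B assay, with a stated time of 48 h (on this read-out higher numbers stand for weaker inhibition of growth and lower numbers for stronger inhibition of growth), compound 1 gives > 100000 nM, which is a limit of the assay and not a number. In this assay compound 2 gives > 100000 nM, again only a limit. Both results therefore rest on (the limit of > 100000 nM in this assay, at which 2 of the 2 values shown sit). Compound 3 `COc1ccc(OC)c(/C=C/C(=O)N/N=C/c2ccccc2)c1` differs from compound 2 by hydrogen in place of chloro on an aromatic carbon. For the measured compounds named here, no measured step of this kind exists here, so no change beyond the usual scatter is expected. Compound 3 is therefore estimated at 100000 nM, within a range from 30000 nM to 300000 nM. The step of a number no higher from compound 2 to compound 3 (the limit leaves the size open) is expected to stay within the scatter.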

Compound 3, concentration for total growth inhibition: 33600 nM
For compound 3 the middle estimate is 3.0-fold (0.47 log units) above the measured one, and the stated range covers the measured number.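

In this assay, among the compounds shown here, going from 4-chlorophenyl to phenyl gives an at least 2.9-fold lower number from compound 2 to compound 3 (0.47 log units; beyond the scatter), so compound 3 holds the only value here that is not a limit. At this place on the ring, then, growth inhibition responds to the change, and the chloro is not needed for a readable effect. The real size of the step stays open because compound 2 rests on a limit: the limit of > 100000 nM in this assay, at which 2 of the 3 values shown sit.

The compounds shown leave open whether a fluoro or an amino group at this place would read like hydrogen or like chloro. They also leave open whether removing the chloro would act alike on the core of compound 1.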